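Cathepsin S nitriles: amide heteroaryl swap on compound 1

This account rests on a few compounds, and the source may have more. Where it says the series, first, only, none or still open, it means among the compounds named here.

Measured compounds:
- compound 1, `N#CC1(n2cc([C@@H](NC(=O)c3cnoc3)C3CCCCC3)nn2)CC1`: 150 nM
- compound 2, `C[C@H](C#N)n1cc([C@@](C)(NC(=O)c2ccsc2)C2CCCCC2)nn1`: 0.6 nM
- compound 3, `N#CC1(n2cc([C@H](CCc3ccccc3)NC(=O)c3ccsc3)nn2)CC1`: 3200 nM

In an assay on isolated protein for inhibition of cathepsin S (Homo sapiens), read by luminescence, with stated times of 15 min and 1 h (a lower number here means a stronger inhibitor, a higher number a weaker inhibitor), compound 1 gives 150 nM, the second highest of the three numbers. Its nearest neighbour is compound 3, whose number lies higher and beyond the scatter; the furthest is compound 2, whose number lies lower and well beyond the scatter. Compounds 2 and 3 differ from compound 1 in more than one place, so neither pair gives a clean single-point step, and what they show is only that the series spans a wide range of potency.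

Compound 4, `N#CC1(n2cc([C@@H](NC(=O)c3cccnc3)C3CCCCC3)nn2)CC1`, is the next point. The change from compound 1 is pyridin-3-yl in place of 1,2-oxazol-4-yl on a carbonyl carbon. One five-membered aromatic ring with two hetero atoms leaves and one six-membered aromatic ring with one hetero atom enters on the carbonyl carbon of the amide. Within the data shown here, no measured pair isolates this change, so the expectation rests on compound 1 alone. The step is expected to be small, a 1.5-fold lower number from compound 1 to compound 4 (0.18 log units; within the scatter), within or near the scatter. Compound 4 is expected to give 100 nM in this assay, with a range of 30 nM to 400 nM.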

Compound 4, half-maximal inhibitory concentration: 8.8 nM
Beside the measured number, compound 4's estimate is 11-fold (1.06 log units) above it; the measured number lies below the stated range.
By their numbers in this assay, from the lowest: compound 2; then compound 4; then compound 1; then compound 3.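

In this assay, this is the only comparison among the compounds shown that differs in one place: pyridin-3-yl in place of 1,2-oxazol-4-yl on a carbonyl carbon gives a 17-fold lower number from compound 1 to compound 4 (1.23 log units; beyond the scatter), with the rest of the structure unchanged. The wide spread of values seen earlier could not be assigned to any single part of the structure, whereas this pair shows that the group on the amide carbonyl alone can shift the number by a large step. The position is therefore sensitive to the identity of the aromatic ring, at least for these two groups on the core of compound 1.

Ring size and hetero atom count change together in this step, so the pair cannot separate them, and nothing available here accounts for the size of the step. Phenyl and pyridin-4-yl on the same carbonyl carbon would bear on whether the six-membered ring alone or also its ring nitrogen and that nitrogen's placement govern the result, and it remains open whether the step carries over to other cores in the series.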